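The source may report more compounds than this note shows. Statements on the series, on what has been measured and on what is new or still open speak of the compounds shown alone.

Compound 1 `CC(C)n1ncc2c(C(=O)NC3CCCC3)cccc21` gives a limit of > 40000 nM in a functional assay on MCF7 cells (Homo sapiens) for inhibition, read by MTT assay, with a stated time of 72 h; on this read-out higher numbers stand for weaker inhibition and lower numbers for stronger inhibition.
Compound 2 `CC(C)n1ncc2c(C(=O)NCc3ccccc3)cccc21` gives a limit of > 40000 nM in this assay.
Compound 3 `CC(C)n1ncc2c(C(=O)NCc3cn(-c4cccc(F)c4)nn3)cccc21` gives a limit of > 40000 nM in this assay.

All three share one core, and in each case the number is a limit of the measurement rather than a measured value: the cells were not inhibited within the tested range. Compound 3 thus stands at the limit, as shown by the limit of > 40000 nM in this assay, at which 3 of the 3 values shown sit. Among the measured compounds shown here, the one step between measured compounds, a step that the two limits leave unreadable from compound 1 to compound 2, has no readable size: both of its ends are limits. Compound 4 `COc1ccc(-n2cc(CNC(=O)c3cccc4c3cnn4C(C)C)nn2)cc1` differs from compound 3 in one place: 4-methoxyphenyl in place of 3-fluorophenyl on an aromatic nitrogen. For the measured compounds named here, no measured step bears on this exchange, and every value so far sits at the limit, so nothing points to a change beyond the scatter. The step expected here, a step that the limit leaves unreadable from compound 3 to compound 4, is none beyond the scatter, with a limit again the most likely outcome. Compound 4 is therefore expected to give about 50000 nM in this assay, in a range from 15000 nM to 200000 nM.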

Compound 4, half-maximal inhibitory concentration: > 40000 nM
Compound 4: a limit, no number; the forecaster's own chance of this, stated with the estimate: 85%; the middle value lies beyond the limit too.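

The swap from 3-fluorophenyl to 4-methoxyphenyl gives no readable step between compound 3 and compound 4, as both results are limits of the assay: the limit of > 40000 nM in this assay, at which 4 of the 4 values shown sit.

The compounds shown leave open which change to the shared core, if any, would give a measured number rather than a limit in this assay.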